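Chloro substitution carried over to the diethylamino analogue

The source may report more compounds than this note shows. Statements on the series, on what has been measured and on what is new or still open speak of the compounds shown alone.

Compound 2 `CN(C)Cc1ccc2nc(NC(=O)N/N=C/c3cn(Cc4ccccc4)c4ccccc34)sc2c1` and compound 1 `CN(C)Cc1ccc2nc(NC(=O)N/N=C/c3cn(Cc4ccccc4Cl)c4ccccc34)sc2c1` share one core; compound 1 carries chloro in place of hydrogen on an aromatic carbon. In a functional assay on NCI-H460 cells (Homo sapiens) for cytotoxicity, read by MTT assay, with a stated time of 72 h (a lower number here means a stronger inhibitor, a higher number a weaker inhibitor), compound 2 gives 400 nM and compound 1 gives 1600 nM, so this change produces a 4.0-fold higher number from compound 2 to compound 1 (0.60 log units; beyond the scatter). Compound 3 `CCN(CC)Cc1ccc2nc(NC(=O)N/N=C/c3cn(Cc4ccccc4)c4ccccc34)sc2c1` differs from compound 2 by diethylamino in place of dimethylamino on a saturated chain carbon bound to an aromatic carbon; in this assay compound 3 gives 450 nM, and the step is a 1.1-fold higher number from compound 2 to compound 3 (0.05 log units; within the scatter), so the two values are not separated. Compound 4 `CCN(CC)Cc1ccc2nc(NC(=O)N/N=C/c3cn(Cc4ccccc4Cl)c4ccccc34)sc2c1` has not yet been measured; relative to compound 3 it carries chloro in place of hydrogen on an aromatic carbon, which is the same change as that from compound 2 to compound 1, at a place described in identical words. The expectation rests on compound 1, whose step a 4.0-fold higher number from compound 2 to compound 1 (0.60 log units; beyond the scatter) is beyond the scatter, and on compound 3, whose value 450 nM sits close to that of compound 2. Compound 4 is therefore expected to show a 4.0-fold higher number from compound 3 to compound 4 (0.60 log units; beyond the scatter) in this assay. The estimate for compound 4 in this assay is 1800 nM, with a range from 800 nM to 4000 nM.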

Compound 4, half-maximal inhibitory concentration: 980 nM
Estimate against measurement, compound 4: 1.8-fold (0.26 log units) above; the range from low to high includes it.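

In this assay, chloro in place of hydrogen on the diethylamino core gives a 2.2-fold higher number from compound 3 to compound 4 (0.34 log units; beyond the scatter), so the change carries over in direction, and its size on the two cores is not separated: the same change on two cores in this assay, a 4.0-fold higher number (0.60 log units; beyond the scatter) from compound 2 to compound 1 and a 2.2-fold higher number (0.34 log units; beyond the scatter) from compound 3 to compound 4, 1.8-fold (0.26 log units) apart, within the scatter of two such steps

Diethylamino in place of dimethylamino with the chloro present gives a 1.6-fold lower number from compound 1 to compound 4 (0.21 log units; within the scatter), and this step likewise cannot be told apart from its counterpart without the chloro: the same change on two cores in this assay, a 1.1-fold higher number (0.05 log units; within the scatter) from compound 2 to compound 3 and a 1.6-fold lower number (0.21 log units; within the scatter) from compound 1 to compound 4, 1.8-fold (0.26 log units) apart, within the scatter of two such steps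

These two pairs support carrying either change between these closely related cores in this one cell assay, but they do not show that the same holds on any other core, and they give no explanation for the step that chloro produces.

Open, from the compounds shown here alone, is how other groups in place of the chloro, such as fluoro, methyl or methoxy, would compare on either core. Also open, going by these compounds, is whether other amines, such as pyrrolidine or morpholine, would leave the chloro step as it stands here.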